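The source may hold more compounds than are shown below. What is called first, only, known or untested is meant among the compounds shown, and "the series" means these compounds.

Measured so far in a functional assay on CEM-DNR-bulk cells (Homo sapiens), read by MTT assay, with a stated time of 72 h; on this read-out lower numbers stand for stronger inhibition and higher numbers for weaker inhibition:
Compound 1, `Cc1nc(N)c2c(-c3ccccc3)cn([C@@H]3O[C@H](CO)[C@@H](O)[C@H]3O)c2n1`, gives > 20000 nM, which is a limit of the assay and not a number.
Compound 2, `O=c1[nH]cnc2c1c(-c1cc3ccccc3o1)cn2[C@@H]1O[C@H](CO)[C@@H](O)[C@H]1O`, gives > 20000 nM, again a limit and not a number.
Compound 3, `Cc1nc(N)c2c(-c3cc4ccccc4o3)cn([C@@H]3O[C@H](CO)[C@@H](O)[C@H]3O)c2n1`, gives 6310 nM.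

Compound 3 and compound 1 differ in a single place: phenyl in place of 1-benzofuran-2-yl on an aromatic carbon. This change produced an at least 3.1-fold higher number from compound 3 to compound 1 (0.50 log units; beyond the scatter), so compound 3, which carries 1-benzofuran-2-yl, is the only one of the three with a measured number, while compound 1 went beyond the limit. Compound 2 carries the same 1-benzofuran-2-yl group on a different core; how its core differs from that of compound 3 is not broken down here. Compound 4, `O=c1[nH]cnc2c1c(-c1ccccc1)cn2[C@@H]1O[C@H](CO)[C@@H](O)[C@H]1O`, is not yet measured. It differs from compound 2 by phenyl in place of 1-benzofuran-2-yl on an aromatic carbon, the same change that leads from compound 3 to compound 1, at a place described in the same words. In this assay the step from compound 2 to compound 4 is expected to be a step that the limit leaves unreadable from compound 2 to compound 4, resting on the earlier step of an at least 3.1-fold higher number from compound 3 to compound 1 (0.50 log units; beyond the scatter) and on (the limit of > 20000 nM in this assay, at which 2 of the 3 values shown sit), where compound 2 already stands. Compound 4 is estimated at 40000 nM, most likely reported only as a limit.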

Compound 4, half-maximal inhibitory concentration: > 20000 nM
Compound 4: only a limit was reported (the forecaster's own chance of this, stated with the estimate: 90%); the middle value is on the limit's open side.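

Compound 2 and compound 4 both sit at a limit of the assay and not at a number, so the step between them cannot be read: the limit of > 20000 nM in this assay, at which 3 of the 4 values shown sit.

The compounds shown leave open how far past that limit each lies, and whether phenyl in place of 1-benzofuran-2-yl acts on their core as on the core of compound 3, where it gave an at least 3.1-fold higher number from compound 3 to compound 1 (0.50 log units; beyond the scatter).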